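The source may hold more compounds than are shown below. What is called first, only, known or untested is meant among the compounds shown, and "the series" means these compounds.

Working notes on the series.

In an assay on isolated protein for inhibition of sodium-dependent phosphate transport protein 2B (Homo sapiens) (on this read-out higher numbers stand for weaker inhibition and lower numbers for stronger inhibition), compound 1 `CCC(CC)N(CCN(C)C(=O)CCC(=O)O)Cc1cccc(C(=O)Nc2sc3c(c2C(=O)c2cnn(-c4ccc(Cl)cc4)c2)CCCC3)c1` gives 118 nM. Among the measured compounds shown here, compound 3 `CCC(CC)N(CCN(C)C(=O)CCC(=O)O)Cc1cccc(C(=O)Nc2sc3c(c2C(=O)c2cnn(-c4ccc(Cl)cc4)c2)CCC(C)(C)C3)c1` gives 36 nM in this assay, the lowest of the two numbers so far; the nearest number is that of compound 1, which sits higher by a margin beyond the usual scatter. Compound 2 `CCC(CC)N(CCN(C)C(=O)CCC(=O)O)Cc1cccc(C(=O)Nc2sc3c(c2C(=O)c2cnn(-c4ccc(Cl)cc4)c2)CCN(C(C)=O)C3)c1` reaches only a limit in this assay, recorded as > 1000 nM, so no number stands for it. That reading is the limit of > 1000 nM in this assay, at which 1 of the 3 values shown sits.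

Compound 4 `CCC(CC)N(CCN(C)C(=O)CCC(=O)O)Cc1cccc(C(=O)Nc2sc3c(c2C(=O)c2cnn(Cc4cccc(C(=O)O)c4)c2)CCC(C)(C)C3)c1` is not yet measured. It differs from compound 3 in one place: 3-carboxybenzyl in place of 4-chlorophenyl on an aromatic nitrogen, in words 3-carboxybenzyl in place of 4-chlorophenyl on an aromatic nitrogen. No measured pair covers a change of this kind, so nothing in the numbers shown points the direction. The change is large in what it brings in and takes away, so a step beyond the scatter is expected rather than none, and the expectation leans toward a higher number. The expected step from compound 3 to compound 4 is a 4.2-fold higher number from compound 3 to compound 4 (0.62 log units; beyond the scatter). Compound 4 is therefore estimated at 150 nM in this assay, with a range from 30 nM to 800 nM.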

Compound 4, half-maximal inhibitory concentration: > 1000 nM
Compound 4: a limit, no number; the forecaster's own chance of this, stated with the estimate: 15%; middle value at least 6.6-fold (0.82 log units) from the limit.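

In this assay compound 4 reaches only a limit, > 1000 nM, and no number stands for it. This is the first change shown on the aromatic nitrogen, where all earlier compounds carry 4-chlorophenyl, and it shows that this place does not accept every group: 3-carboxybenzyl in place of 4-chlorophenyl, with the rest of compound 3 kept, gives an at least 27-fold higher number from compound 3 to compound 4 (1.44 log units; beyond the scatter), a large step. The size of that step is a lower bound only, and the series now has as many limits as it has numbers: the limit of > 1000 nM in this assay, at which 2 of the 4 values shown sit.

The compounds shown leave open which part of the change carries the loss, as the carboxylic acid and the benzyl link enter together in a single step. An unsubstituted benzyl group on the same nitrogen, a phenyl ring bearing a carboxylic acid, or a methyl ester or primary amide in place of the acid would separate these parts, and how each of them reads on this target remains an open question.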